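Swapping a benzyl for a propyl on the shared core

The compounds below may be only part of what the source reports. "The series", "measured", "known", "first", "only" and "open" are said of these compounds alone.

Among the measured compounds shown here, compound 2 `[O-][n+]1nc(NCOCc2ccccc2)[n+]([O-])c2ccccc21` stands highest of the two numbers so far in a functional assay on PC-3 cells (Homo sapiens) for cytotoxicity, read by MTT assay, with a stated time of 72 h (a lower number here means a stronger inhibitor, a higher number a weaker inhibitor), with compound 2 giving 13400 nM. Its nearest neighbour is compound 1 `COCNc1n[n+]([O-])c2ccccc2[n+]1[O-]`, which gives 7510 nM in this assay, and the step of a 1.8-fold higher number from compound 1 to compound 2 (0.25 log units; within the scatter) falls within the scatter. Compound 3 `CCCOCNc1n[n+]([O-])c2ccccc2[n+]1[O-]` is the untested member, differing from compound 2 by ethyl in place of phenyl on a saturated chain carbon bound to an oxygen on a saturated carbon. For the measured compounds named here, only one measured step bears on this change, the one from compound 1 to compound 2, which added a phenyl at the same place and moved the number by a 1.8-fold higher number from compound 1 to compound 2 (0.25 log units; within the scatter), no more than repeated measurements wander. Removing the phenyl again and leaving an ethyl in its place is therefore expected to give a step of about a 1.4-fold lower number from compound 2 to compound 3 (0.15 log units; within the scatter), no clear direction beyond the scatter. Compound 3 is estimated at 9500 nM, expected to lie between 4500 nM and 20000 nM.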

Compound 3, half-maximal inhibitory concentration: 14200 nM
Compound 3: the middle estimate sits 1.5-fold (0.17 log units) below what was measured, and the stated range covers the measured number.
By their numbers in this assay, from the lowest: compounds 1, 2 and 3 (each within the scatter of the next).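

In this assay the step of a 1.1-fold higher number from compound 2 to compound 3 (0.03 log units; within the scatter) shows that the six-membered aromatic ring can give way to an open ethyl chain on a saturated chain carbon bound to an oxygen on a saturated carbon without leaving the scatter. The step of a 1.9-fold higher number from compound 1 to compound 3 (0.28 log units; within the scatter) adds the comparison with hydrogen, so hydrogen, ethyl and phenyl have now been compared at this place, and none of the three pairs stands apart beyond the scatter. Nothing available explains why these three groups give such similar numbers.

From the compounds shown here alone, whether an amine, a carboxylic acid or a much longer chain at this place would move the number beyond the scatter remains open. So does whether these three compounds would also stay this close together on another cell line.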